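Adding a Third Methoxy to the Aryl of Compound 2

This account rests on a few compounds, and the source may have more. Where it says the series, first, only, none or still open, it means among the compounds named here.

Measured in a functional assay on the whole organism (strain albino) for inhibition, with Rattus norvegicus as the target, read by paw edema, with a stated time of 3 h, at a dose of 0.28 mmol/kg by the oral route; a lower number here means less inhibition, a higher number more inhibition at the dose given (going by the name of the read-out):
compound 1 `C=CCn1c(SC/C(=N\O)c2ccccc2)nnc1-c1ccc(OC)c(OC)c1`: 58%
compound 2 `C=CCn1c(SCC(=O)c2ccccc2)nnc1-c1ccc(OC)c(OC)c1`: 64%
compound 3 `C=CCn1c(SCC(=O)c2ccccc2)nnc1-c1ccc(OC)cc1`: 63%

Compound 2 gives 64% in this assay, and the other two numbers sit within the scatter of it: compound 3 gives 63% and compound 1 gives 58%. Compound 4 `C=CCn1c(SCC(=O)c2ccccc2)nnc1-c1cc(OC)c(OC)c(OC)c1` differs from compound 2 by methoxy in place of hydrogen on an aromatic carbon. The step that bears on this is a number 1 percentage points lower from compound 2 to compound 3 (within the scatter), a methoxy removed from the same aromatic ring with no effect beyond the scatter. The step of a number 6 percentage points higher from compound 1 to compound 2 (within the scatter) concerns the chain near the sulfur and bears little here. Adding a further methoxy is therefore expected to move the read-out by a number 2 percentage points lower from compound 2 to compound 4 (within the scatter), not beyond the scatter. For compound 4 the estimated value in this assay is 62%, with a range from 50% to 74%.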

Compound 4, a percentage reported as inhibition, in the whole organism at one dose (the size of the read-out at that dose, not a potency): 66%
Estimate against measurement, compound 4: 4 percentage points below; the measured number falls inside the stated range.
By their numbers in this assay, from the lowest: compounds 1, 3, 2 and 4 (each within the scatter of the next).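

In this assay the aromatic carbon ortho to a methoxy group carries a further methoxy with a number 2 percentage points higher from compound 2 to compound 4 (within the scatter) and no loss of the read-out beyond the scatter. Together with the removal of a methoxy from the same ring, a number 1 percentage points lower from compound 2 to compound 3 (within the scatter) and also within the scatter, this leaves the read-out flat on both sides of compound 2. No measured property offers a reason for this flat response.

Open at this carbon are a hydroxyl, a chlorine, an ethoxy group or an amine. A single oral dose also leaves open whether compound 2 and compound 4 would separate at lower doses.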